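The source may report more compounds than this note shows. Statements on the series, on what has been measured and on what is new or still open speak of the compounds shown alone.

Among the compounds with values here, compound 1, whose structure is `CC(C)n1cc(-c2ccnc3[nH]c(C4CCN(CC(=O)N5CCCC5)CC4)cc23)ccc1=O`, is one of only two compounds measured so far in an ADME assay on cells (Hepatocyte, Homo sapiens) for metabolic stability; a higher number here means faster removal of the compound, a lower number slower removal. In this assay compound 1 gives 3.5 uL/min, the lower of the two numbers. The other measured compound, compound 2, with the structure `COc1cc(C(=O)N2CCCC2)ccc1-c1ccnc2[nH]c(C3CCOCC3)cc12`, gives 46 uL/min in this assay, and this gap from compound 1 lies well beyond the usual scatter. Within the data shown here, compound 2 differs from compound 1 in several places at once, so the two values on their own show only that numbers can spread widely; no single change has yet been tied to a step of known size.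

The next compound, compound 3, has the structure `CC(C)n1cc(-c2ccnc3[nH]c(C4CCN(CC(=O)N(C)C)CC4)cc23)ccc1=O`. It differs from compound 1 in a single place: dimethylamino in place of pyrrolidin-1-yl on a carbonyl carbon. Among the measured compounds shown here, with no measured pair that isolates this change, the expectation rests on compound 1 alone: the step of a 1.1-fold higher number from compound 1 to compound 3 (0.06 log units; within the scatter) is expected to be small and to stay within the scatter, in either direction. Compound 3 is therefore estimated at 4 uL/min, in the range 2 uL/min to 9 uL/min.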

Compound 3, intrinsic clearance in a liver preparation (reported as CLH), per the amount of preparation that the assay uses: < 1 uL/min
Compound 3: no number, only a limit; the forecaster's own chance of this, stated with the estimate: 10%; middle value at least 4.0-fold (0.60 log units) from the limit.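

In this assay, this pair gives the first step tied to a single change in the series: with the rest of the structure held fixed, dimethylamino in place of pyrrolidin-1-yl on a carbonyl carbon goes with an at least 3.5-fold lower number from compound 1 to compound 3 (0.54 log units; beyond the scatter). This shows that the group on this carbonyl carbon can move the clearance read-out beyond the usual scatter, even though the change removes only a small ring and leaves the shared core of compound 1 untouched. Compound 3 gives < 1 uL/min, which is a limit of the assay and not a number, so the full size of the step stays unknown because the value rests on that limit: the limit of < 1 uL/min in this assay, at which 1 of the 3 values shown sits.

One pair cannot tell whether the step follows from losing the ring, from having fewer heavy atoms, or from something specific to dimethylamino. It also leaves open where other groups on the same carbonyl carbon, such as piperidin-1-yl, morpholin-4-yl or diethylamino, would fall, and whether the same swap would give a step of similar direction on a different core.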